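The compounds below may be only part of what the source reports. "The series", "measured", "known", "first", "only" and "open" are said of these compounds alone.

Compound 1 `CC1(C)CC(OC(=O)CN2CN(c3ccccc3)C3(CCN(C(=O)c4ccc(C(C)(C)C)cc4)CC3)C2=O)CC(C)(C)N1`: 1300 nM
Compound 2 `O=C(CN1CN(c2ccccc2)C2(CCN(C(=O)c3ccc(C4CCCCC4)cc3)CC2)C1=O)N1CCCCC1`: 1100 nM
Compound 3 `O=C(CN1CN(c2ccccc2)C2(CCN(C(=O)c3ccc(C4CCCCC4)cc3)CC2)C1=O)NCO`: 8300 nM

All three share one core and were measured in an assay on HEK293 cells for displacement of a labelled ligand from NPC1-like intracellular cholesterol transporter 1 (Homo sapiens); a lower number here means a stronger inhibitor, a higher number a weaker inhibitor. Compound 1 gives the second highest of the three numbers; compound 2 lies within the scatter of it, so the two cannot be ordered, while compound 3 lies beyond the scatter at a clearly higher number. Going by the values given here, compound 4 `CC1CCCN(C(=O)CN2CN(c3ccccc3)C3(CCN(C(=O)c4ccc(C(C)(C)C)cc4)CC3)C2=O)C1` is compound 1 altered at a single spot: 3-methylpiperidin-1-yl in place of (2,2,6,6-tetramethylpiperidin-4-yl)oxy on a carbonyl carbon Only one measured step touches the same carbonyl carbon, a 7.5-fold higher number from compound 2 to compound 3 (0.88 log units; beyond the scatter), where a cyclic amine was exchanged for a group with a hydrogen-bond donor and the number rose modestly but beyond the scatter. The change to compound 4 runs the other way: the group leaving carries the hydrogen-bond donor, and the group entering is a cyclic amine much like that of compound 2. Among the compounds with values here, no step tells how the tert-butyl of compound 1 compares with the cyclohexyl of compound 2, so the expectation rests on that single step alone. Compound 4 is therefore expected to give a number close to compound 2. The step from compound 1 is expected to be a 1.4-fold lower number from compound 1 to compound 4 (0.16 log units; within the scatter), within the scatter. For compound 4 the estimate is 900 nM, expected to fall between 300 nM and 3000 nM.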

Compound 4, half-maximal inhibitory concentration: 12000 nM
For compound 4 the middle estimate is 13-fold (1.12 log units) below the measured one, and the stated range ends below it.
By their numbers in this assay, from the lowest: compounds 2 and 1 (each within the scatter of the next); then compounds 3 and 4 (each within the scatter of the next).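

Replacing (2,2,6,6-tetramethylpiperidin-4-yl)oxy with 3-methylpiperidin-1-yl gives a 9.2-fold higher number from compound 1 to compound 4 (0.97 log units; beyond the scatter) in this assay, so a cyclic amine on this carbonyl carbon does not by itself go with a low number. The other step at this place, a 7.5-fold higher number from compound 2 to compound 3 (0.88 log units; beyond the scatter), also raises the number, yet there a group with a hydrogen-bond donor enters, whereas here one leaves; the presence of a donor therefore does not predict the direction across these two pairs. No measurement shown here accounts for the rise.

This single change alters several things at once: the atom joined to the carbonyl carbon, the size of the group, the hydrogen-bond donors and acceptors, and the methyl substitution, so the compounds shown cannot say which of these matters. A (2,2,6,6-tetramethylpiperidin-4-yl)amino group on the same carbonyl carbon would separate the linking oxygen from the rest of the group, and an unsubstituted piperidin-1-yl group alongside the tert-butyl of compound 4 would isolate the contribution of the 3-methyl.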